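The source may report more compounds than this note shows. Statements on the series, on what has been measured and on what is new or still open speak of the compounds shown alone.

Three compounds have been measured in a functional assay on HT-29 cells (Homo sapiens) for cytotoxicity, read by MTT assay, with a stated time of 6 days (on this read-out higher numbers stand for weaker inhibition and lower numbers for stronger inhibition), so far:

- compound 1 `COc1ccc2c(c1)OCC(=O)N2Cc1cn(Cc2ccccc2)nn1` gives 9300 nM
- compound 2 `Cc1cc2c(cc1Cl)N(Cc1cn(Cc3ccccc3)nn1)C(=O)CO2` gives 19600 nM
- compound 3 `O=C1COc2ccc(Cl)cc2N1Cc1cn(Cc2ccccc2)nn1` gives 76500 nM

Compound 3 stands highest of the three, which makes it the weakest inhibitor measured, and both other values lie beyond the scatter from it. Still unmeasured is compound 4 `COc1ccc2c(c1)N(Cc1cn(Cc3ccccc3)nn1)C(=O)CO2` and its relation to compound 3 is simple. The change is methoxy in place of chloro on an aromatic carbon and amounts to methoxy in place of chloro on an aromatic carbon.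

Among the measured compounds shown here, no measured step tests this exchange directly. For the measured compounds named here, the only single-place step, a 3.9-fold higher number from compound 2 to compound 3 (0.59 log units; beyond the scatter) and concerns hydrogen in place of methyl, so it shows only that one small substituent can shift the number modestly here. Going by the values given here, the sole measured compound with a methoxy group is compound 1 at 9300 nM and it carries that group at another place on the core, so it offers only indirect support. A modest step towards a lower number is therefore expected in this assay for this exchange, with considerable uncertainty. The estimate means an expected 3.1-fold lower number from compound 3 to compound 4 (0.49 log units; beyond the scatter) and this would leave it within the range of the measured compounds. For compound 4 the expected value is 25000 nM with an estimated range from 8000 nM to 75000 nM in this read-out.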

Compound 4, half-maximal inhibitory concentration: > 100000 nM
Compound 4 gave a limit, no number; the forecaster's own chance of this, stated with the estimate: 5%; middle value at least 4.0-fold (0.60 log units) away from the limit.
By their numbers in this assay, from the lowest: compound 1; then compound 2; then compound 3. At a limit, above all of these: compound 4.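

Compound 4 gave a limit and not a number in this assay: the limit of > 100000 nM in this assay, at which 1 of the 4 values shown sits. At this place on the ring, meta to a fused ring and para to a fused ring, methoxy in place of chloro brought no lower number, and the step is an at least 1.3-fold higher number from compound 3 to compound 4 (0.11 log units; that floor lies within the scatter), so only a floor is known and that floor does not by itself separate the two compounds. The earlier compounds had shown only that a small substituent can shift the number on this core, and compound 1, which carries its methoxy group at another place on the core, gives 9300 nM, a value that now proves not to carry over to this position.

On these data alone, how far compound 4 really lies from compound 3 stays open, since a limit cannot be turned into a size of step. The compounds shown also leave open whether a different group at this place, such as an amine, a hydroxyl or a longer chain like ethoxy, would give a lower number than chloro does.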